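The compounds below may be only part of what the source reports. "The series", "measured", "known", "first", "only" and "open" are said of these compounds alone.

Working notes on the series. Of the compounds shown here, three have been measured in a functional assay on SMMC-7721 cells (Homo sapiens) for cytotoxicity, read by MTT assay, with a stated time of 72 h (a lower number here means a stronger inhibitor, a higher number a weaker inhibitor), and one remains to be run. Compound 1 `O=C(CSC(=S)N[C@H]1CCOC1=O)Nc1ccc(Cl)cc1Cl` gives only a limit, > 128000 nM, and so no number, in this assay (the limit of > 128000 nM in this assay, at which 1 of the 3 values shown sits). Compound 2 `CCCCCCCCSC(=S)N[C@H]1CCOC1=O` gives 65100 nM in this assay. Compound 3 `O=C(CCl)Nc1ccc(C(=O)/C=C/c2ccc(Cl)cc2)cc1`, built on a different core from the first two, gives 8160 nM in this assay, the lowest of the two numbers available; the nearest number, that of compound 2, lies well beyond the scatter from it.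

Compound 4 `O=C(CCl)Nc1ccc(C(=O)/C=C/c2ccc([N+](=O)[O-])cc2)cc1` keeps the core of compound 3 and differs from it in one place: nitro in place of chloro on an aromatic carbon, para to a large group. Among the compounds with values here, no measured pair in the set shows this exchange, so nothing here sets its size. For this assay the step is expected to be small, no larger than the scatter of repeats, and if anything toward a lower number; the estimate corresponds to a step of a 1.4-fold lower number from compound 3 to compound 4 (0.13 log units; within the scatter). Compound 4 is therefore estimated at 6000 nM in this assay, with a range from 2000 nM to 18000 nM.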

Compound 4, half-maximal inhibitory concentration: 9060 nM
Beside the measured number, compound 4's estimate is 1.5-fold (0.18 log units) below it; the measured number falls inside the stated range.
By their numbers in this assay, from the lowest: compounds 3 and 4 (each within the scatter of the next); then compound 2. At a limit, above all of these: compound 1.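

In this assay, nitro in place of chloro on an aromatic carbon, para to a large group, gives a 1.1-fold higher number from compound 3 to compound 4 (0.05 log units; within the scatter). Within the data shown here, this is the first measured exchange between two compounds that differ in one place, and it shows that, on this core, a group with hydrogen-bond acceptors can replace one with none at this position without a change beyond the scatter. No measurement at hand accounts for this step, so the pair gives only its size and no reason for it.

Still open, going by these compounds, is whether this position stays as flat for groups of a different kind, such as an amine, a carboxylic acid or a longer chain, or whether any group placed there moves the number beyond the scatter. Among these compounds, also open is whether the same exchange would give a step of like size on another core, as this single pair is the only reading of it so far.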